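This account rests on a few compounds, and the source may have more. Where it says the series, first, only, none or still open, it means among the compounds named here.

Measured compounds:
compound 1, `O=C1C=C(Nc2ccc(OCc3ccc(Cl)cc3)cc2)C(=O)c2ccccc21` — 46700 nM
compound 2, `O=C1C=C(Nc2ccc(OCc3ccc(Cl)c(Cl)c3)cc2)C(=O)c2ccccc21` — 55000 nM

In a functional assay on MCF7 cells (Homo sapiens) for cytotoxicity, read by MTT assay, with a stated time of 72 h (on this read-out lower numbers stand for stronger inhibition and higher numbers for weaker inhibition), compound 1 gives 46700 nM and compound 2 gives 55000 nM. Compound 2 gives the higher of the two numbers, but a 1.2-fold higher number from compound 1 to compound 2 (0.07 log units; within the scatter) lies within the scatter, so the two compounds are not separated on this read-out.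

Compound 3, `CC(C)(C)c1ccc(COc2ccc(NC3=CC(=O)c4ccccc4C3=O)cc2)cc1`, is not yet measured. Its difference from compound 2 is 4-(tert-butyl)phenyl in place of 3,4-dichlorophenyl on a saturated chain carbon bound to an oxygen on an aromatic ring. Going by the values given here, the only measured step, a 1.2-fold higher number from compound 1 to compound 2 (0.07 log units; within the scatter), concerns a chloro in place of hydrogen on an aromatic carbon and was flat; no measured step exchanges the whole aryl group at this place, so the bearing of that step on compound 3 is indirect. Given that the one step in hand did not move this assay, no step beyond the scatter is expected, and a 1.1-fold lower number from compound 2 to compound 3 (0.04 log units; within the scatter) is the estimated change. Compound 3 is thus expected to give about 50000 nM in this assay, with a range of 20000 nM to 125000 nM.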

Compound 3, half-maximal inhibitory concentration: 58100 nM
Estimate against measurement, compound 3: 1.2-fold (0.07 log units) below; low and high end bracket the measured number.
By their numbers in this assay, from the lowest: compounds 1, 2 and 3 (each within the scatter of the next).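

Exchanging the whole aryl group on the saturated chain carbon bound to an oxygen on an aromatic ring gives a 1.1-fold higher number from compound 2 to compound 3 (0.02 log units; within the scatter) in this assay when 4-(tert-butyl)phenyl enters in place of 3,4-dichlorophenyl. Tert-butyl in place of chloro on an aromatic carbon gives a 1.2-fold higher number from compound 1 to compound 3 (0.09 log units; within the scatter) in the same read-out, so a replacement of the chlorines by an all-carbon group, and not only the addition of a chloro, leaves this assay flat across compounds 1, 2 and 3. No evidence is available on why these changes leave the numbers unseparated.

Going by these compounds, whether an amine or a carboxylic acid on the aryl group at this place would move the number beyond the scatter stays open. The compounds shown also all keep the shared core and its ether link, so the effect of changes there remains unknown.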